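Hydroxymethyl for methoxy at the assay limit

A few compounds are considered here, and "the series" means these few. Any claim that something is new, unique, unknown or untested is made for them only; others in the source may bear on it.

In an ADME assay on PBMC cells (Homo sapiens) for activation (a lower number here means a stronger inhibitor, a higher number a weaker inhibitor), compound 1 `COc1ccc(-c2cc3c(NC(CC(N)=O)c4ccccc4)ncnc3s2)cc1` gives > 30000 nM as a limit of the assay and not a number. In this assay compound 2 `COc1cc(CO)ccc1-c1cc2c(Nc3ccc(OCc4cccc(F)c4)c(Cl)c3)ncnc2s1` gives 28000 nM as a measured number. Compound 3 `NC(=O)CC(Nc1ncnc2sc(-c3ccc(CO)cc3)cc12)c1ccccc1` carries hydroxymethyl in place of methoxy on an aromatic carbon on the otherwise unchanged structure of compound 1. Among the compounds with values here, no measured step covers this change, so no step beyond the scatter is expected in this assay in either direction. Compound 3 is estimated at 30000 nM with an expected range from 12000 nM to 60000 nM in this series.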

Compound 3, half-maximal inhibitory concentration: > 10000 nM
Compound 3 was reported as a limit; the forecaster's own chance of this, stated with the estimate: 65%; the middle value lies beyond the limit too.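

In this assay no step can be read between compound 1 and compound 3, as both values are limits of the assay and not numbers. The compounds shown leave open whether hydroxymethyl in place of methoxy on an aromatic carbon shifts the half-maximal inhibitory concentration in either direction.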